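Swapping iodo for difluoromethoxy in compound 2

The compounds below may be only part of what the source reports. "The series", "measured", "known", "first", "only" and "open" are said of these compounds alone.

Of the compounds shown here, three with a shared core have been measured in a functional assay on M21 cells (Homo sapiens) for antiproliferative activity, read by sulforhodamine B assay, with a stated time of 48 h; on this read-out higher numbers stand for weaker inhibition and lower numbers for stronger inhibition. Compound 1 `CCc1ccccc1NS(=O)(=O)c1ccc(N2CCNC2=O)cc1` gives 180 nM, compound 2 `O=C1NCCN1c1ccc(S(=O)(=O)Nc2ccc(I)cc2)cc1` gives 260 nM, and compound 3 `CCc1cccc(NS(=O)(=O)c2ccc(N3CCNC3=O)cc2)c1` gives 82 nM. Compound 2 has the highest of these numbers, but it cannot be separated from its nearest neighbour, as there is a 1.4-fold higher number from compound 1 to compound 2 (0.16 log units; within the scatter). The gap to the furthest compound is clearer, with a 3.2-fold lower number from compound 2 to compound 3 (0.50 log units; beyond the scatter).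

Compound 4 `O=C1NCCN1c1ccc(S(=O)(=O)Nc2ccc(OC(F)F)cc2)cc1` has not yet been measured. It carries difluoromethoxy in place of iodo on an aromatic carbon, para to a large group: difluoromethoxy in place of iodo on an aromatic carbon. Among the measured compounds shown here, no measured pair makes this exact swap, so the evidence is indirect. The three measured steps all change the group on the sulfonamide nitrogen, as this swap also does. Besides the two steps above, there is a 2.2-fold lower number from compound 1 to compound 3 (0.34 log units; beyond the scatter). These steps range from within the scatter to modest, so no step beyond the scatter is expected in this assay, although a modest move in either direction would not be surprising. The expected change is a 1.1-fold lower number from compound 2 to compound 4 (0.03 log units; within the scatter). Compound 4 is estimated at 240 nM, with an expected range from 100 nM to 600 nM.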

Compound 4, half-maximal inhibitory concentration: 410 nM
Estimate against measurement, compound 4: 1.7-fold (0.23 log units) below; measured number inside the range.
By their numbers in this assay, from the lowest: compound 3; then compounds 1, 2 and 4 (each within the scatter of the next, the first and the last beyond it).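

Among the compounds shown here, compounds 2 and 4 are the first pair here to keep the place on the ring fixed, para to a large group, and change only what sits there. The earlier comparisons shown here, such as a 3.2-fold lower number from compound 2 to compound 3 (0.50 log units; beyond the scatter), altered the group and its place together. In this assay, the new comparison gives a 1.6-fold higher number from compound 2 to compound 4 (0.20 log units; within the scatter), so the two compounds cannot be told apart, even though iodo has 1 heavy atom and no hydrogen-bond acceptor while difluoromethoxy has 4 heavy atoms and 1 hydrogen-bond acceptor. At this place, then, the read-out does not separate these two quite different groups. Nothing measured on the compounds themselves bears on why this is so.

From the compounds shown here alone, it remains open whether this holds for other kinds of group at the same place, such as an amine or a carboxylic acid, or for a longer chain. The compounds also leave open how much of the gap between the 4-iodophenyl and 3-ethylphenyl compounds comes from the group and how much from its place, and an ethyl group at the place studied here would help to separate the two.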